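Side chain change from compound 3 to compound 4

The source may report more compounds than this note shows. Statements on the series, on what has been measured and on what is new or still open speak of the compounds shown alone.

Measured in a functional assay on A-427 cells (Homo sapiens) for cytotoxicity, read by colorimetric assay and MTT assay; a lower number here means a stronger inhibitor, a higher number a weaker inhibitor:
- compound 1 `COc1cc(OC)c2cc(-c3ccccc3)c(O)nc2c1`: 10000 nM
- compound 2 `CCOC(=O)Cn1c(=O)c(-c2ccc(OC)cc2)cc2c(OC)cc(OC)cc21`: 10000 nM
- compound 3 `CCN(CC)C(=O)Cn1c(=O)c(-c2ccc(OC)cc2)cc2c(OC)cc(OC)cc21`: 10000 nM

Among the measured compounds shown here, compound 3, at 10000 nM, stands level with compound 1 and compound 2 in this assay, so the series so far shows no spread. The next structure is compound 4 `COc1ccc(-c2cc3c(OC)cc(OC)cc3n(CC#N)c2=O)cc1`, with cyano in place of diethylcarbamoyl on a saturated chain carbon bound to an aromatic nitrogen. The same difference, cut one bond further out, reads (diethylcarbamoyl)methyl to cyanomethyl. For the measured compounds named here, one measured step bears on this chain: no change at the digits printed from compound 2 to compound 3 (within the scatter). That step also swaps the group carried on the chain, and it gave no movement. Compound 1, which lacks the chain altogether, also gives 10000 nM. Going by the values given here, no measured compound carries cyano, so the data cannot exclude a departure from this flat picture. No step beyond the scatter is expected. The expected size of the change is no change at the digits printed from compound 3 to compound 4 (within the scatter). For compound 4 the estimated value is 10000 nM, with an expected range of 4000 nM to 20000 nM.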

Compound 4, half-maximal inhibitory concentration: 10000 nM
Beside the measured number, compound 4's estimate shows no gap at the digits printed; the range from low to high includes it.
By their numbers in this assay, from the lowest: compounds 1, 2, 3 and 4 (each within the scatter of the next).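

In this assay, the change on a saturated chain carbon bound to an aromatic nitrogen now reaches beyond swaps among carbonyl groups: cyano in place of diethylcarbamoyl gives no change at the digits printed from compound 3 to compound 4 (within the scatter) and cyano in place of ethoxycarbonyl gives no change at the digits printed from compound 2 to compound 4 (within the scatter) in the same assay. Ethoxycarbonyl, diethylcarbamoyl and cyano thus read alike at this place, so a carbonyl on the chain is not required for this level. Nor does the much smaller cyano, against diethylcarbamoyl, shift the reading.

Still open, as far as these compounds go, is whether any group here can move the value off this shared level, for example a chain ending in a primary amine or a carboxylic acid, or a longer chain carrying the nitrile. No supporting measurement accounts for the flat reading at this place.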